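From ethyl to bromo on the shared core

This account rests on a few compounds, and the source may have more. Where it says the series, first, only, none or still open, it means among the compounds named here.

Measured in a functional assay on UACC-62 cells (Homo sapiens) for inhibition, read by sulforhodamine B assay, with a stated time of 48 h; a higher number here means a weaker inhibitor of growth, a lower number a stronger inhibitor of growth:
Compound 1 `Cc1ccc(NC(=S)N/N=C/c2cccs2)cc1`: 16800 nM
Compound 2 `CCc1ccc(NC(=S)N/N=C/c2cccs2)cc1`: > 100000 nM, a limit and not a number

Compound 2 gives no number, and it stands at the limit of > 100000 nM in this assay, at which 1 of the 2 values shown sits. Compound 3 `S=C(N/N=C/c1cccs1)Nc1ccc(Br)cc1` has not yet been measured. It carries bromo in place of ethyl on an aromatic carbon.

Among the measured compounds shown here, only one measured step bears on this change, and it concerns the group that now leaves. That step is an at least 5.9-fold higher number from compound 1 to compound 2 (0.77 log units; beyond the scatter). From the compounds shown here alone, it is beyond the scatter, but its full size is unknown. With the ethyl gone, a step towards a lower number in this assay is expected, though it is poorly defined. For the measured compounds named here, compound 1, the only reference with a number, gives 16800 nM.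

The expected change is an at least 3.3-fold lower number from compound 2 to compound 3 (0.52 log units; beyond the scatter). Compound 3 is estimated at 30000 nM, with an expected range of 8000 nM to 100000 nM.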

Compound 3, concentration for 50% growth inhibition: 71100 nM
Estimate against measurement, compound 3: 2.4-fold (0.37 log units) below; low and high end bracket the measured number.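

In this assay, compound 3 shows that this place on the aromatic ring tolerates a group other than methyl and still gives a measured number, yet bromo in place of methyl gives a 4.2-fold higher number from compound 1 to compound 3 (0.63 log units; beyond the scatter), so methyl in compound 1 keeps the lowest number of the three. The change from ethyl to bromo gives an at least 1.4-fold lower number from compound 2 to compound 3 (0.14 log units; that floor lies within the scatter), so the compounds do not establish that bromo improves on ethyl by more than the scatter. Compound 2 stands at a limit of the assay and not at a number, so the full size of that step stays unknown: the limit of > 100000 nM in this assay, at which 1 of the 3 values shown sits.

The compounds shown leave open whether a chloro, a methoxy or an amine at this place would come closer to compound 1. They also leave open how far compound 2 really lies from compound 3.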